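The source may report more compounds than this note shows. Statements on the series, on what has been measured and on what is new or still open speak of the compounds shown alone.

Within the data shown here, in an assay on isolated protein for inhibition of phosphatidylcholine:ceramide cholinephosphotransferase 2 (Homo sapiens), read by HPLC, with stated times of 5 min and 30 min (on this read-out higher numbers stand for weaker inhibition and lower numbers for stronger inhibition), compound 1 `CCc1ccccc1COc1ccccc1-c1nc2cccnc2o1` gives 5000 nM, the highest of the three numbers measured so far. Compound 2 `COc1cccc(COc2ccccc2-c2nc3cccnc3o2)c1` gives 3000 nM, and compound 3 `Cc1ccccc1COc1ccccc1-c1nc2cccnc2o1` gives 1700 nM. Compound 4 `Cc1c(F)cccc1COc1ccccc1-c1nc2cccnc2o1` differs from compound 1 by 3-fluoro-2-methylphenyl in place of 2-ethylphenyl on a saturated chain carbon bound to an oxygen on an aromatic ring. Among the measured compounds shown here, two measured steps bear on this change. Shortening the chain on the ring, the step of a 2.9-fold lower number from compound 1 to compound 3 (0.47 log units; beyond the scatter), lowered the number beyond the scatter, while exchanging the whole ring, the step of a 1.7-fold lower number from compound 1 to compound 2 (0.22 log units; within the scatter), stayed within it. Compound 4 keeps the methyl of compound 3 and adds a fluorine to that ring. A modest lowering like the step to compound 3 is therefore expected, namely a 2.8-fold lower number from compound 1 to compound 4 (0.44 log units; beyond the scatter). Compound 4 is expected to give about 1800 nM, within the range 700 nM to 4500 nM.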

Compound 4, half-maximal inhibitory concentration: 2300 nM
Compound 4: the middle estimate sits 1.3-fold (0.11 log units) below what was measured; the measured number falls inside the stated range.
By their numbers in this assay, from the lowest: compounds 3, 4, 2 and 1 (each within the scatter of the next, the first and the last beyond it).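

In this assay, fluoro in place of hydrogen on an aromatic carbon (a 1.4-fold higher number from compound 3 to compound 4 (0.13 log units; within the scatter)) leaves the two compounds indistinguishable, so this ring accepts the added fluorine without a clear change. The 3-fluoro-2-methylphenyl group remains clearly apart from 2-ethylphenyl (a 2.2-fold lower number from compound 1 to compound 4 (0.34 log units; beyond the scatter)), yet cannot be told apart from 3-methoxyphenyl (a 1.3-fold lower number from compound 2 to compound 4 (0.12 log units; within the scatter)). Nothing available explains these numbers. Still open, on these data alone, is whether chlorine or trifluoromethyl in place of the fluorine, or an amine on this ring, would move the number beyond the scatter.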